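A few compounds are considered here, and "the series" means these few. Any claim that something is new, unique, unknown or untested is made for them only; others in the source may bear on it.

Measured so far in a functional assay on HeLa cells (Homo sapiens) for cytotoxicity, read by MTT assay, with a stated time of 48 h; a higher number here means a weaker inhibitor, a lower number a stronger inhibitor

compound 1 `COc1cc(/C=C/C(=O)C2=C(/C=C/c3ccc(O)c(OC)c3)NC(=S)NC2c2ccc(C)cc2)ccc1O` gives 25000 nM
compound 2 `COc1cc(/C=C/C(=O)C2=C(/C=C/c3ccc(O)c(OC)c3)NC(=S)NC2c2ccccc2O)ccc1O` gives 25000 nM
compound 3 `COc1cc(/C=C/C(=O)C2=C(/C=C/c3ccc(O)c(OC)c3)NC(=S)NC2c2c(Cl)cccc2Cl)ccc1O` gives 100000 nM

Compound 3 has the highest number of the three, and its gap to each of the other two lies beyond the scatter. Compound 4 `COc1cc(/C=C/C(=O)C2=C(/C=C/c3ccc(O)c(OC)c3)NC(=S)NC2c2ccccc2Cl)ccc1O` differs from it at one place, 2,6-dichlorophenyl to 2-chlorophenyl, with hydrogen in place of chloro on an aromatic carbon. Going by the values given here, no measured step makes exactly this change. The closest guides are the two steps that bring in the 2,6-dichlorophenyl group (a 4.0-fold higher number from compound 1 to compound 3 (0.60 log units; beyond the scatter); a 4.0-fold higher number from compound 2 to compound 3 (0.60 log units; beyond the scatter)), both modest and in the same direction. The 4-methylphenyl and 2-hydroxyphenyl compounds do not separate (no change at the digits printed from compound 1 to compound 2 (within the scatter)). Among the compounds with values here, no measured compound carries a single chloro, so the share of the gap that one chloro retains is unknown. Compound 4 is therefore expected to fall part of the way from compound 3 at 100000 nM towards compound 1 at 25000 nM in this assay. The expected change is a 2.2-fold lower number from compound 3 to compound 4 (0.35 log units; beyond the scatter) and is estimated to be smaller than the full measured gap. For compound 4 the estimated value is 45000 nM in this assay, with an expected range from 20000 nM to 100000 nM around it.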

Compound 4, half-maximal inhibitory concentration: 50000 nM
For compound 4 the middle estimate is 1.1-fold (0.05 log units) below the measured one; low and high end bracket the measured number.
By their numbers in this assay, from the lowest: compounds 1, 2, 4 and 3 (each within the scatter of the next, the first and the last beyond it).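

Going by these compounds alone, compound 4 is the first compound here with a single chloro on this aryl group, and in this assay hydrogen in place of chloro on an aromatic carbon gives a 2.0-fold lower number from compound 3 to compound 4 (0.30 log units; within the scatter). Compared with the other two aryl groups, the 2-chlorophenyl compound also stays close, with chloro in place of hydroxy on an aromatic carbon giving a 2.0-fold higher number from compound 2 to compound 4 (0.30 log units; within the scatter) and the change of the whole aryl group giving a 2.0-fold higher number from compound 1 to compound 4 (0.30 log units; within the scatter). Only the 2,6-dichlorophenyl compound stands beyond the scatter from compounds 1 and 2, while compound 4 lies within the scatter of all three, so this position tolerates the loss of one chloro without a readable change, and the single chloro cannot be assigned to either side of that gap.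

No measurement in hand bears on why the aryl groups rank as they do. Still open, from the compounds shown here alone, is whether a dimethylamino group, a carboxylic acid or a methoxy group on this aryl ring would leave the numbers in this narrow band or move them beyond the scatter, and whether a single chloro placed elsewhere on the ring would behave like the 2-chlorophenyl compound.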